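The source may hold more compounds than are shown below. What is called first, only, known or untested is meant among the compounds shown, and "the series" means these compounds.

Measured compounds:
- compound 1 `Cn1c2cnc1OCCCCCCCCCOc1ccccc1-2` — in a functional assay on U-373MG ATCC cells (Homo sapiens) for inhibition, read by colorimetric assay and MTT assay, with a stated time of 72 h (on this read-out lower numbers stand for stronger inhibition and higher numbers for weaker inhibition), compound 1 gives 78000 nM
- compound 2 `CCCCOc1ncc(-c2ccccc2OC)n1C` — in this assay compound 2 gives "not determined" (no result reported)

Going by the values given here, compound 1 and compound 2 do not share a one-point difference, so no step between them can be stated; compound 1 is a ring-closed analogue and compound 2 an open-chain one, and the two sit on different scaffolds. On the numbers shown, compound 2 therefore stands nowhere: no half-maximal inhibitory concentration is recorded for it, and the only measured value in the set is the weak one of compound 1.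

Compound 3 `C=CCCCCOc1ncc(-c2ccccc2OC)n1C` is to be tested in this assay. It is built from compound 2 by the change (vinyl in place of hydrogen on a saturated chain carbon, four bonds along the chain from an oxygen on an aromatic ring). Among the compounds with values here, with no step between measured compounds in this assay, no size can be anchored for this change; a modest step, within the usual scatter, is the working assumption, with no direction preferred.

Given the weak value of compound 1 78000 nM as the only point of reference, compound 3 is expected to fall around 60000 nM, with a plausible range of 15000 nM to 200000 nM.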

Compound 3, half-maximal inhibitory concentration: 9000 nM
Beside the measured number, compound 3's estimate is 6.7-fold (0.82 log units) above it; measured number outside the range, below it.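

In this assay compound 3 gives 9000 nM but no step can be read from it, as compound 2 has no number there and compound 1 differs from compound 3 in more than one place. No measured evidence bears on this value. The compounds shown leave open what vinyl in place of hydrogen on the chain does to inhibition.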